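Fluoro Gives Way to Acetamido on the Sulfonyl-Bound Ring

A few compounds are considered here, and "the series" means these few. Any claim that something is new, unique, unknown or untested is made for them only; others in the source may bear on it.

In a functional assay on SMMC-7721 cells (Homo sapiens) for cytotoxicity, read by MTT assay, with a stated time of 24 h (a lower number here means a stronger inhibitor, a higher number a weaker inhibitor), compound 1 `COc1cc(/C=C2\CN(S(=O)(=O)c3ccc(F)cc3)C/C(=C\c3cccc([N+](=O)[O-])c3)C2=O)cc(OC)c1OC` gives 4900 nM, compound 2 `COc1cc(/C=C2\CN(S(=O)(=O)c3ccc(F)cc3)C/C(=C\c3ccc(C#N)cc3)C2=O)cc(OC)c1OC` gives 4120 nM and compound 3 `COc1cc(/C=C2\CN(S(=O)(=O)c3ccc(F)cc3)C/C(=C\c3cc(OC)c(OC)c(OC)c3)C2=O)cc(OC)c1` gives 5420 nM. Compound 2 therefore stands level with both of the others, within the scatter of each. Compound 4 `COc1cc(/C=C2\CN(S(=O)(=O)c3ccc(NC(C)=O)cc3)C/C(=C\c3ccc(C#N)cc3)C2=O)cc(OC)c1OC` keeps the rest of compound 2 and alters one group: acetamido in place of fluoro on an aromatic carbon. Acetamido takes the place of fluoro on an aromatic carbon, para to a large group, so 4-fluorophenyl becomes 4-acetamidophenyl.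

The measured steps all concern a different site, the aromatic group on a double-bonded chain carbon: a 1.2-fold lower number from compound 1 to compound 2 (0.08 log units; within the scatter), a 1.1-fold higher number from compound 1 to compound 3 (0.04 log units; within the scatter) and a 1.3-fold higher number from compound 2 to compound 3 (0.12 log units; within the scatter). None of them touches the fluoro site, so the data hold no direct test of this change. For the measured compounds named here, they show only that these three values stay together when that other group is exchanged. No shift beyond the scatter is therefore expected, though with real uncertainty. The expected size is a 1.1-fold higher number from compound 2 to compound 4 (0.04 log units; within the scatter). For compound 4 the estimated value is 4500 nM, with an expected range from 1800 nM to 11000 nM.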

Compound 4, half-maximal inhibitory concentration: 1730 nM
Compound 4: middle estimate off by 2.6-fold (0.42 log units), on the high side; measured number below the stated range.
By their numbers in this assay, from the lowest: compound 4; then compounds 2, 1 and 3 (each within the scatter of the next).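

In this assay, for the compounds shown here, acetamido in place of fluoro on an aromatic carbon gives a 2.4-fold lower number from compound 2 to compound 4 (0.38 log units; beyond the scatter), a modest change but the only step in this set that lies beyond the scatter. The earlier exchanges all concerned the aromatic group on the double-bonded chain carbon and left the numbers level, so this fluoro site is the first shown to shift the number at all. The data shown include no measurement that could explain the shift, so its origin remains unknown.

The compounds shown leave open whether the same exchange would shift the number when 3-nitrophenyl or 3,5-dimethoxyphenyl replaces the 4-cyanophenyl group of compound 2. They also leave open whether the whole acetamido group is needed, or whether a simple amine or a longer amide chain at the same place would give a similar result.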